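Chloro in Place of Cyano: Expected Clearance for Compound 4

This account rests on a few compounds, and the source may have more. Where it says the series, first, only, none or still open, it means among the compounds named here.

Compound 1 `N#Cc1ccc2c(-c3ccc(Cl)cc3)c(S(=O)(=O)c3ccc(F)cc3)cnc2c1`: 0.01 mL/min
Compound 2 `N#Cc1ccc2ncc(S(=O)(=O)c3ccc(F)cc3)c(-c3ccc(Cl)cc3)c2c1`: 0.04 mL/min
Compound 3 `O=S(=O)(c1ccc(F)cc1)c1cnc2ccc(Cl)cc2c1-c1ccc(Cl)cc1`: 0.2 mL/min

In an ADME assay on microsomes from liver (Rattus norvegicus) for metabolic stability, tested at 2.5 uM (on this read-out higher numbers stand for fast clearance and lower numbers for slow clearance), compound 1 gives the lowest of the three numbers, compound 2 a higher one and compound 3 the highest. Compound 1 and compound 2 share the same atoms joined differently; the difference between the two cores is not broken down here. From compound 2 to compound 3 the change is chloro in place of cyano on an aromatic carbon, and it produced a 5.0-fold higher number from compound 2 to compound 3 (0.70 log units; beyond the scatter). Compound 4 `O=S(=O)(c1ccc(F)cc1)c1cnc2cc(Cl)ccc2c1-c1ccc(Cl)cc1` carries the same change on the core of compound 1, (chloro in place of cyano on an aromatic carbon), at a place described in the same words. Compound 4 is therefore expected to show a step of a 5.0-fold higher number from compound 1 to compound 4 (0.70 log units; beyond the scatter) in this assay, resting on the measured rise from compound 2 to compound 3. The estimate for compound 4 is 0.05 mL/min, with a range of 0.02 mL/min to 0.15 mL/min.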

Compound 4, intrinsic clearance in a liver preparation (reported as CLH), per the amount of preparation that the assay uses: 0.01 mL/min
The estimate for compound 4 lay 5.0-fold (0.70 log units) above the measured number; measured number outside the range, below it.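

In this assay, chloro in place of cyano on an aromatic carbon gave no change at the digits printed from compound 1 to compound 4 (within the scatter), so the change did not carry the rise seen on the other core over to the core of compound 1. This shows that, in this series, the step measured on one core was no safe guide to the step on the other, though two pairs cannot show why the cores part or which result would hold on a further core. The two steps differ: the same change on two cores in this assay, a 5.0-fold higher number (0.70 log units; beyond the scatter) from compound 2 to compound 3 and no change at the digits printed (within the scatter) from compound 1 to compound 4, 5.0-fold (0.70 log units) apart, beyond the scatter of two such steps

The compounds shown leave open how an amine or a carboxylic acid in place of the cyano would behave on either core. They also leave open whether the two cores would part in the same way with those groups.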